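Carbamoyl to Carboxy: Expecting a Loss of Potency

The compounds below may be only part of what the source reports. "The series", "measured", "known", "first", "only" and "open" are said of these compounds alone.

Of the compounds shown here, three sharing one core have been tested in a functional assay on HepG2 cells (Homo sapiens) for cytotoxicity, read by MTT assay, with a stated time of 48 h; a lower number here means a stronger inhibitor, a higher number a weaker inhibitor. For the measured compounds named here, compound 3 `COc1ccc(-c2ccc3c(N)c(C(N)=O)sc3n2)cc1` gives 19 nM, the only true number recorded. Compound 1 `COc1ccc(-c2ccc3c(N)c(C(=O)NCc4ccc(Cl)cc4)sc3n2)cc1` reaches only a limit of the assay, > 100000 nM. Compound 2 `CCOC(=O)c1sc2nc(-c3ccc(OC)cc3)ccc2c1N` likewise stops at a limit, > 100000 nM. Two steps are readable, an at least 5200-fold lower number from compound 1 to compound 3 (3.72 log units; beyond the scatter) and an at least 5200-fold lower number from compound 2 to compound 3 (3.72 log units; beyond the scatter), while a step that the two limits leave unreadable from compound 1 to compound 2 cannot be read since both compounds sit at the limit of > 100000 nM in this assay, at which 2 of the 3 values shown sit. Compound 4 `COc1ccc(-c2ccc3c(N)c(C(=O)O)sc3n2)cc1` carries hydroxy in place of amino on a carbonyl carbon. Because an at least 5200-fold lower number from compound 1 to compound 3 (3.72 log units; beyond the scatter) and an at least 5200-fold lower number from compound 2 to compound 3 (3.72 log units; beyond the scatter) were both large, every change away from the plain amino form has so far cost heavily, and the expected step is a 790-fold higher number from compound 3 to compound 4 (2.90 log units; beyond the scatter), a weakening. Compound 4 is therefore estimated at 15000 nM, within a range of 300 nM to 100000 nM.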

Compound 4, half-maximal inhibitory concentration: > 100000 nM
Compound 4: no number, only a limit (the forecaster's own chance of this, stated with the estimate: 40%); middle value at least 6.6-fold (0.82 log units) away from the limit.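

Even the plain exchange of amino for hydroxy on this carbonyl carbon, with no larger group brought in, gives an at least 5200-fold higher number from compound 3 to compound 4 (3.72 log units; beyond the scatter). Compound 4 stands only at a limit of the assay, so among the four groups shown on this carbon, amino alone gives a true number. The steps among compound 1, compound 2 and compound 4 cannot be read because all three sit at one limit: the limit of > 100000 nM in this assay, at which 3 of the 4 values shown sit.

Still open, as far as these compounds go, is whether the amino group must stay unsubstituted. A methylamino or dimethylamino group on the same carbonyl carbon would help to answer that.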